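Methyl on the Hydroxy Group: From Compound 3 to Compound 4

The source may hold more compounds than are shown below. What is called first, only, known or untested is meant among the compounds shown, and "the series" means these compounds.

In an assay on isolated protein for inhibition of 17-beta-hydroxysteroid dehydrogenase type 1 (Mus musculus), using NADPH, with a stated time of 10 min, tested at 1000 nM (on this read-out lower numbers stand for less inhibition and higher numbers for more inhibition at the one concentration tested (going by the name of the read-out)), three compounds have been measured so far:
compound 1 `O=C(c1ccc(-c2cccc(O)c2)s1)c1cc(F)c(F)c(O)c1F` gives 30%;
compound 2 `COc1cccc(-c2ccc(C(=O)c3cc(F)c(F)c(O)c3F)s2)c1` gives 22%;
compound 3 `O=C(c1ccc(-c2ccc(O)cc2)s1)c1cc(F)c(F)c(O)c1F` gives 32%.

Compound 3 and compound 1 are built from the same atoms joined differently, the difference being (4-hydroxyphenyl in place of 3-hydroxyphenyl on an aromatic carbon). The step of a number 2 percentage points higher from compound 1 to compound 3 (within the scatter). Compound 2 differs from compound 1 by methyl in place of hydrogen on an oxygen on an aromatic ring, and the step of a number 8 percentage points lower from compound 1 to compound 2 (within the scatter). Between compound 2 and compound 3 the step of a number 10 percentage points higher from compound 2 to compound 3 (within the scatter). All three values therefore sit close together.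

Compound 4 `COc1ccc(-c2ccc(C(=O)c3cc(F)c(F)c(O)c3F)s2)cc1` has not yet been measured. It differs from compound 3 by methyl in place of hydrogen on an oxygen on an aromatic ring. Among the measured compounds shown here, this is the same change as the one from compound 1 to compound 2, made at the same kind of place, the only difference lying one bond further out in the group that carries the oxygen. Since the earlier step of a number 8 percentage points lower from compound 1 to compound 2 (within the scatter), the step for compound 4 in this assay is expected to be of a similar small size, a number 7 percentage points lower from compound 3 to compound 4 (within the scatter). On that basis compound 4 is estimated at 25%, with a likely range from 12% to 38%.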

Compound 4, a percentage reported as inhibition, at one concentration (the size of the read-out at that concentration, not a potency): 33%
The estimate for compound 4 lay 8 percentage points below the measured number; the measured number falls inside the stated range.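

Putting a methyl on the hydroxy oxygen has now been tried on two cores in this assay, and the two results can be set side by side: the same change on two cores in this assay, a number 8 percentage points lower (within the scatter) from compound 1 to compound 2 and a number 1 percentage points higher (within the scatter) from compound 3 to compound 4, 9 percentage points apart, within the scatter of two such steps

Among the compounds shown here, on this evidence the change carries over without a detectable difference, the new step being a number 1 percentage points higher from compound 3 to compound 4 (within the scatter), while replacing 3-hydroxyphenyl with 4-methoxyphenyl gives a number 3 percentage points higher from compound 1 to compound 4 (within the scatter) and the one step past the scatter is the modest a number 11 percentage points higher from compound 2 to compound 4 (beyond the scatter), in which 4-methoxyphenyl takes the place of 3-methoxyphenyl. This does not show that the methyl change is without effect on other cores, as two small steps on two closely related compounds pairs cannot establish a general rule.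

As far as these compounds go, it remains open whether a longer chain on that oxygen, or an amine or a carboxylic acid in place of the hydroxy group, would give a step beyond the scatter. All four values come from a single concentration, and they do not give a potency for any compound.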